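The source may report more compounds than this note shows. Statements on the series, on what has been measured and on what is new or still open speak of the compounds shown alone.

Going by the values given here, in a functional assay on MCF7 cells (Homo sapiens) for cytotoxicity, read by MTT assay, with a stated time of 96 h (on this read-out higher numbers stand for weaker inhibition and lower numbers for stronger inhibition), compound 1 (`COc1cc(C(=O)c2cn(-c3ccc(F)cc3)cc2-c2ccccc2F)cc(OC)c1OC`) gives 39 nM and compound 2 (`COc1cc(C(=O)c2cn(-c3ccc(F)cc3)cc2-c2ccccc2[N+](=O)[O-])cc(OC)c1OC`) gives 38 nM, so compound 2 stands level with the only other measured compound. Compound 3 (`COc1cc(C(=O)c2cn(-c3ccc(F)cc3)cc2-c2cccc([N+](=O)[O-])c2)cc(OC)c1OC`) differs from compound 2 as follows: 3-nitrophenyl in place of 2-nitrophenyl on an aromatic carbon, with 3-nitrophenyl in place of 2-nitrophenyl on an aromatic carbon. Among the compounds with values here, the sole measured step, a 1.0-fold lower number from compound 1 to compound 2 (0.01 log units; within the scatter), exchanged fluoro for nitro and did not test a change between these two nitrophenyl groups, so it offers only weak guidance and no direction. No shift beyond the scatter is therefore expected in this assay, and the expected step is a 1.2-fold higher number from compound 2 to compound 3 (0.07 log units; within the scatter). Compound 3 is estimated at 45 nM, with an expected range of 12 nM to 170 nM.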

Compound 3, half-maximal inhibitory concentration: 440 nM
Estimate against measurement, compound 3: 9.8-fold (0.99 log units) below; measured number above the stated range.
By their numbers in this assay, from the lowest: compounds 2 and 1 (each within the scatter of the next); then compound 3.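

In this assay, the same atoms rearranged as 3-nitrophenyl in place of 2-nitrophenyl give a 12-fold higher number from compound 2 to compound 3 (1.06 log units; beyond the scatter), so this place on the shared core responds strongly to where the nitro group sits on the phenyl ring. The exchange of 2-fluorophenyl for 3-nitrophenyl gives a step of similar size, an 11-fold higher number from compound 1 to compound 3 (1.05 log units; beyond the scatter), whereas fluoro and nitro in the 2-substituted phenyl groups had stood level. No measurement bearing on the origin of this loss is available. From the compounds shown here alone, whether the loss is specific to nitro remains open. A 3-aminophenyl or 3-fluorophenyl group at this place would separate the substituent from its ring position.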